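Notes on the shared core series, compound 4 pending

The compounds below may be only part of what the source reports. "The series", "measured", "known", "first", "only" and "open" are said of these compounds alone.

Measured so far in a functional assay on the whole organism (strain Wistar) for inhibition, with Rattus norvegicus as the target, read by paw edema, with stated times of 1 h and 3 h, at a dose of 70 mg/kg by the oral route; on this read-out higher numbers stand for more inhibition at the one dose given (going by the name of the read-out) and lower numbers for less inhibition:
compound 1 `Clc1ccc2nc(Nc3nnc(-c4ccccc4Cl)o3)sc2c1` gives 53%
compound 2 `Clc1ccc(-c2nnc(Nc3nc4ccc(Cl)cc4s3)o2)c(Cl)c1` gives 80%
compound 3 `COC(=O)c1ccccc1-c1nnc(Nc2nc3ccc(Cl)cc3s2)o1` gives 31%

Compound 2 stands highest of the three in this assay, with compound 1 nearest and compound 3 furthest, both beyond the scatter. Two steps are known: a number 27 percentage points higher from compound 1 to compound 2 (beyond the scatter) and a number 22 percentage points lower from compound 1 to compound 3 (beyond the scatter). Both changes sit on the six-membered aromatic ring of carbon only, so what that ring carries moves the read-out. Compound 4 `Sc1nnc(Nc2nc3ccc(Cl)cc3s2)o1` differs from compound 2 by sulfanyl in place of 2,4-dichlorophenyl on an aromatic carbon; the ring that carried those substituents leaves altogether. Going by the values given here, no measured step removes that ring, so the size is uncertain; because a number 27 percentage points higher from compound 1 to compound 2 (beyond the scatter) and a number 22 percentage points lower from compound 1 to compound 3 (beyond the scatter) were each modest, a drop beyond the scatter is expected, a number 45 percentage points lower from compound 2 to compound 4 (beyond the scatter). For compound 4 the estimate is 35%, range 15% to 60%.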

Compound 4, a percentage reported as inhibition, in the whole organism at one dose (the size of the read-out at that dose, not a potency): 61.7%
The estimate for compound 4 lay 26.7 percentage points below the measured number, outside the stated range (above it).
By their numbers in this assay, from the lowest: compound 3; then compounds 1 and 4 (each within the scatter of the next); then compound 2.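

In this assay, the aromatic ring at this position can leave altogether with inhibition retained: sulfanyl in place of 2,4-dichlorophenyl gives a number 18.3 percentage points lower from compound 2 to compound 4 (beyond the scatter), a modest loss. Sulfanyl in place of 2-chlorophenyl gives a number 8.7 percentage points higher from compound 1 to compound 4 (within the scatter), so compound 1 and compound 4 cannot be told apart in this read-out, even though the single sulfur replaces a whole ring. Nothing at hand explains why this change costs so little.

Open, going by these compounds, is how an amine or a carboxylic acid would fare at this position on the shared core. Also open, on these data alone, is whether a longer chain on the sulfur would keep the read-out of compound 4.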